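This account rests on a few compounds, and the source may have more. Where it says the series, first, only, none or still open, it means among the compounds named here.

Measured so far in an ADME assay for pharmacokinetics, at pH 7.4; a lower number here means that the compound disappears faster, a higher number that the compound lasts longer:
- compound 1, `COc1ccnc(C[S+]([O-])c2nc3cc(OCC(F)(F)F)ccc3[nH]2)c1OC`: > 200 h
- compound 2, `COc1ccnc(C[S+]([O-])c2nc3cc(OCC(F)(F)F)ccc3[nH]2)c1C`: 5 h
- compound 3, `COc1ccnc(C[S+]([O-])c2nc3cc(F)c(OC(F)F)cc3[nH]2)c1OC`: 150 h

The value of compound 1 in this assay, > 200 h, is a limit of the assay and not a number; it sits at the limit of > 200 h in this assay, at which 1 of the 3 values shown sits. Compound 2 gives 5 h in this assay, and the step of an at least 40-fold lower number from compound 1 to compound 2 (1.60 log units; beyond the scatter) goes with one change, (methyl in place of methoxy on an aromatic carbon). Compound 3 gives 150 h in this assay; the difference between its core and the core of compound 1 is not broken down here.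

Compound 4, `COc1ccnc(C[S+]([O-])c2nc3cc(F)c(OC(F)F)cc3[nH]2)c1C`, has not yet been measured in this assay. For the measured compounds named here, it differs from compound 3 by methyl in place of methoxy on an aromatic carbon, which is the same change as the one made from compound 1 to compound 2, only on the other core. A similarly large drop is expected, so the expected step is a 38-fold lower number from compound 3 to compound 4 (1.57 log units; beyond the scatter), resting on the earlier step of an at least 40-fold lower number from compound 1 to compound 2 (1.60 log units; beyond the scatter) and on the value of compound 3, 150 h. Compound 4 is therefore estimated at 4 h, likely between 1 h and 15 h.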

Compound 4, half-life: 4 h
The estimate for compound 4 equals the measured number at the digits printed; low and high end bracket the measured number.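

In this assay, methyl in place of methoxy on an aromatic carbon gives a large step on the second core as well, a 38-fold lower number from compound 3 to compound 4 (1.57 log units; beyond the scatter), so on both cores shown the change goes with a marked fall in the number. Compound 1 gives > 200 h, which is a limit of the assay and not a number, so the earlier step has no exact size. With only two cores shown, this is no general rule for the series, and the two steps cannot be called equal: the same change on two cores in this assay, an at least 40-fold lower number (1.60 log units; beyond the scatter) from compound 1 to compound 2 and a 38-fold lower number (1.57 log units; beyond the scatter) from compound 3 to compound 4; the limit leaves it open whether they differ

The compounds shown leave open what other groups in this place, such as an ethoxy group, a chlorine atom or an amine, would give in this assay compared with methoxy and methyl. On these data alone, the two cores also differ in more than one place, so what each of those differences does on its own stays open.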